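Thiourea-linked sulfonamide quinazolines: the benzyloxy step

This account rests on a few compounds, and the source may have more. Where it says the series, first, only, none or still open, it means among the compounds named here.

Three compounds of this series have been run in a functional assay on A-431 cells (Homo sapiens) for antiproliferative activity, read by MTT assay, with a stated time of 72 h; on this read-out lower numbers stand for stronger inhibition and higher numbers for weaker inhibition. Compound 1 `COc1cc2ncnc(Nc3cccc(Cl)c3)c2cc1OCCCCC(=O)Nc1ccc(S(N)(=O)=O)cc1` gives 30400 nM in this assay. Compound 2 `COc1cc2ncnc(Nc3ccc(OCc4cccc(F)c4)c(Cl)c3)c2cc1OCCCCC(=O)Nc1ccc(S(N)(=O)=O)cc1` carries one added group; in this assay compound 2 gives 7790 nM. The change between them is (3-fluorobenzyl)oxy in place of hydrogen on an aromatic carbon and it produced a 3.9-fold lower number from compound 1 to compound 2 (0.59 log units; beyond the scatter). Compound 3 `NS(=O)(=O)c1ccc(NC(=S)Nc2ccc3ncnc(Nc4cccc(Cl)c4)c3c2)cc1` rests on a different core from compound 1, and the difference between the two cores is not broken down here; in this assay compound 3 gives 15000 nM, which sits within the scatter of compound 2 and beyond it relative to compound 1.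

Compound 4 `NS(=O)(=O)c1ccc(NC(=S)Nc2ccc3ncnc(Nc4ccc(OCc5cccc(F)c5)c(Cl)c4)c3c2)cc1` has not yet been measured in this assay. It differs from compound 3 by (3-fluorobenzyl)oxy in place of hydrogen on an aromatic carbon. Within the data shown here, this is the same kind of change as the one from compound 1 to compound 2, and the two place descriptions agree word for word, so the only difference between the two occurrences is the core that carries the change. With a single earlier example of this change and no information on how the change behaves on the core of compound 3, the expectation rests on that one step alone.

For compound 4 in this assay the step is therefore expected to be roughly a 3.8-fold lower number from compound 3 to compound 4 (0.57 log units; beyond the scatter), matching the earlier step in direction and size, with a wide band because the core is not the same. Compound 4 is estimated at 4000 nM in this assay, between 1500 nM and 11000 nM.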

Compound 4, half-maximal inhibitory concentration: 29500 nM
For compound 4 the middle estimate is 7.4-fold (0.87 log units) below the measured one; measured number above the stated range.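

In this assay, the (3-fluorobenzyl)oxy change does not carry over from one core to the other as a fixed increment: the same change on two cores in this assay, a 3.9-fold lower number (0.59 log units; beyond the scatter) from compound 1 to compound 2 and a 2.0-fold higher number (0.29 log units; within the scatter) from compound 3 to compound 4, 7.7-fold (0.89 log units) apart, beyond the scatter of two such steps

On the core of compound 3 the change gives a 2.0-fold higher number from compound 3 to compound 4 (0.29 log units; within the scatter), so the lower number seen on the core of compound 1, a 3.9-fold lower number from compound 1 to compound 2 (0.59 log units; beyond the scatter), is not reproduced there, and a step read on one core of this series is a poor guide to the other. Among these compounds, with only one pair on each core, this does not show which part of the cores governs the outcome, nor how any other group would behave when carried across them.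

From the compounds shown here alone, it remains open whether the split follows the thiourea link or another part of the core, and a urea in place of the thiourea, tested with and without (3-fluorobenzyl)oxy, would help to separate these. Also open, going by these compounds, is whether the split is particular to (3-fluorobenzyl)oxy or also holds for a plain benzyloxy group or a methoxy group entering on the same aromatic carbon of both cores.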